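The source may hold more compounds than are shown below. What is called first, only, known or untested is meant among the compounds shown, and "the series" means these compounds.

Measured so far, in a functional assay on HeLa cells (Homo sapiens) for cytotoxicity, read by neutral red uptake, with a stated time of 3 days; a higher number here means a weaker inhibitor, a lower number a stronger inhibitor:
- Compound 1, `C[S+]([O-])c1c(F)c(N)c2c(=O)cc(-c3ccc(N)c(F)c3)oc2c1F`. In this assay compound 1 gives > 100000 nM, a limit of the assay, not a number.
- Compound 2, `[N-]=[N+]=Nc1c(F)c(N)c2c(=O)cc(-c3ccc(N)c(F)c3)oc2c1F`. In this assay compound 2 gives 1200 nM.
- Compound 3, `CCCCCCCCCCCCCCCCCC(=O)OCc1c(F)c(N)c2c(=O)cc(-c3ccc(N)c(F)c3)oc2c1F`. In this assay compound 3 gives > 100000 nM, again a limit of the assay.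

Among the compounds with values here, compound 2 therefore holds the only numeric value in the set; the two other compounds sit at the limit, as summarised by the limit of > 100000 nM in this assay, at which 2 of the 3 values shown sit. Within the data shown here, the single measured step is an at least 83-fold lower number from compound 1 to compound 2 (1.92 log units; beyond the scatter), a large gain in potency on exchanging the group on that aromatic carbon.

Compound 4, `CCCOCc1c(F)c(N)c2c(=O)cc(-c3ccc(N)c(F)c3)oc2c1F`, is not yet measured. It differs from compound 2 as follows: propoxymethyl in place of azido on an aromatic carbon. The only step shown concerns the same aromatic carbon and shows that this position moves the number strongly. Compound 3, which also carries an oxygen-bearing chain through a methylene at that position, reaches only the limit. A large weakening is therefore expected for compound 4, with a fair chance that only a limit is reported. The expected step is a 25-fold higher number from compound 2 to compound 4 (1.40 log units; beyond the scatter). The estimate for compound 4 in this assay is 30000 nM, within 5000 nM to 150000 nM.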

Compound 4, half-maximal inhibitory concentration: 78000 nM
Compound 4: middle estimate off by 2.6-fold (0.41 log units), on the low side; the measured number falls inside the stated range.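

In this assay, the exchange of azido for propoxymethyl gives a 65-fold higher number from compound 2 to compound 4 (1.81 log units; beyond the scatter), so the size of a change at this aromatic carbon can now be read from two numeric values and not only from a floor. Among the groups shown at this position, azido alone gives a number far from the limit of the assay, and compound 4 is the only other numeric value, with the remaining compounds at that limit: the limit of > 100000 nM in this assay, at which 2 of the 4 values shown sit. The comparison with the sulfur-bearing group gives an at least 1.2-fold lower number from compound 1 to compound 4 (0.10 log units; that floor lies within the scatter), a floor that sets no order between the two compounds.

Going by these compounds, it remains open whether another group at this carbon, such as an amine, a nitrile or a carboxylic acid, would come close to azido. Also open, on these data alone, is how a shorter or longer ether chain than propoxymethyl would move the number.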